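Variation on the ring amine nitrogen: compound 4 expected

The source may report more compounds than this note shows. Statements on the series, on what has been measured and on what is new or still open speak of the compounds shown alone.

Compound 1 `O=C1c2ccccc2S(=O)(=O)N1CCCCCCN1CCN(c2ccc(Cl)c(Cl)c2)CC1` carries 3,4-dichlorophenyl on an amine nitrogen in a ring of the shared core. In an ADME assay on HEK293 cells for displacement of a labelled ligand from 5-hydroxytryptamine receptor 7 (Homo sapiens), read by radioligand binding, with a stated time of 1 h (on this read-out lower numbers stand for stronger inhibition and higher numbers for weaker inhibition), compound 1 gives 258 nM. Compound 2 `O=C1c2ccccc2S(=O)(=O)N1CCCCCCN1CCN(c2ccccc2C(F)(F)F)CC1` gives 195 nM and compound 3 `O=C1c2ccccc2S(=O)(=O)N1CCCCCCN1CCN(c2ccccc2)CC1` gives 192 nM. Among the three numbers compound 1 stands highest, yet the step of a 1.3-fold lower number from compound 1 to compound 2 (0.12 log units; within the scatter) and the step of a 1.3-fold lower number from compound 1 to compound 3 (0.13 log units; within the scatter) both stay within the scatter, so no order among the three can be drawn. The step of a 1.0-fold lower number from compound 2 to compound 3 (0.01 log units; within the scatter) is likewise within the scatter.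

Compound 4 `O=C1c2ccccc2S(=O)(=O)N1CCCCCCN1CCN(c2ccccn2)CC1` has not been measured. It differs from compound 1 by pyridin-2-yl in place of 3,4-dichlorophenyl on an amine nitrogen in a ring. All three measured steps bear on this change, since each of them also exchanges the group on that same nitrogen, and none of them moved the number beyond the scatter. Going by the values given here, no measured compound carries a ring with a hetero atom at that place, so that part of the change rests on no data from this series. The expectation for compound 4 is therefore a step of a 1.2-fold lower number from compound 1 to compound 4 (0.07 log units; within the scatter), nothing beyond the scatter. Compound 4 is estimated at 220 nM, with a range from 90 nM to 550 nM.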

Compound 4, inhibition constant: 552 nM
For compound 4 the middle estimate is 2.5-fold (0.40 log units) below the measured one; measured number outside the range, above it.
By their numbers in this assay, from the lowest: compounds 3, 2 and 1 (each within the scatter of the next); then compound 4.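

In this assay, the group on the amine nitrogen in a ring now moves the number beyond the scatter, which none of the exchanges among compounds 1, 2 and 3 did: the new steps are a 2.1-fold higher number from compound 1 to compound 4 (0.33 log units; beyond the scatter), a 2.9-fold higher number from compound 3 to compound 4 (0.46 log units; beyond the scatter) and a 2.8-fold higher number from compound 2 to compound 4 (0.45 log units; beyond the scatter), all of them modest. The step from phenyl to pyridin-2-yl is the plainest reading, as it replaces an aromatic ring of carbon only with a six-membered aromatic ring with 1 hetero atom, whereas adding 3,4-dichloro or 2-trifluoromethyl groups to the phenyl ring left the number within the scatter. No measurement shown here gives a reason for the higher number with pyridin-2-yl.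

The compounds shown leave open whether this higher number goes with pyridin-2-yl alone or also with other rings holding hetero atoms, such as a pyrimidine or a thiophene. They also leave open whether a methoxy group on the pyridine ring, or a shorter chain in the shared core, would keep, widen or remove the step.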